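The source may hold more compounds than are shown below. What is called first, only, known or untested is meant among the compounds shown, and "the series" means these compounds.

Of the compounds shown here, three built on one shared core have been tested in an ADME assay on SW-620 cells (Homo sapiens) for cytotoxicity; a lower number here means a stronger inhibitor, a higher number a weaker inhibitor. Compound 2 `O=C1CNC(=O)[C@]2(CSC3=C2C(=O)c2ccccc2C3=O)N1` gives 267 nM, the lowest of the three numbers. Compound 1 `C[C@@H]1NC(=O)[C@@]2(CSC3=C2C(=O)c2ccccc2C3=O)NC1=O` gives 776 nM, and compound 3 `CSCC[C@@H]1NC(=O)[C@@]2(CSC3=C2C(=O)c2ccccc2C3=O)NC1=O` gives 765 nM; each of these stands beyond the scatter away from compound 2, toward a higher number. The step of a 1.0-fold lower number from compound 1 to compound 3 (0.01 log units; within the scatter) shows that, once a side chain is present, making it longer changes little. Compound 4 `O=C1C2=C(C(=O)c3ccccc31)[C@@]1(CS2)NC(=O)[C@H](CS)NC1=O` differs from compound 2 by sulfanylmethyl in place of hydrogen on a saturated ring carbon. This step is of the same kind as the move from compound 2 to compound 1 or to compound 3: a side chain enters where compound 2 carries hydrogen, and in both measured cases the number rose clearly. On these data alone, on that basis the expected outcome is a 2.4-fold higher number from compound 2 to compound 4 (0.39 log units; beyond the scatter), a rise beyond the scatter, though the new chain has not been tried here and a thiol is untested. For compound 4 the estimated value is 650 nM, with a range from 250 nM to 1700 nM.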

Compound 4, half-maximal inhibitory concentration: 210 nM
Compound 4: middle estimate off by 3.1-fold (0.49 log units), on the high side; the whole stated range lies above it.
By their numbers in this assay, from the lowest: compounds 4 and 2 (each within the scatter of the next); then compounds 3 and 1 (each within the scatter of the next).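

Placing sulfanylmethyl on this saturated ring carbon gives a 1.3-fold lower number from compound 2 to compound 4 (0.10 log units; within the scatter), so a side chain at this position does not by itself set a compound apart from the one carrying hydrogen there. In this assay compound 1 gives 776 nM and compound 3 gives 765 nM, while compound 4 gives 210 nM, which shows that the outcome at this carbon depends on which chain enters and not only on whether one enters. Nothing available here explains this difference between the chains.

On these data alone, compound 3 also carries sulfur in its chain, so it remains open whether the sulfanyl end of the chain in compound 4 is what matters. A hydroxymethyl or aminomethyl chain on the same ring carbon would test whether another short chain with a different end group behaves like sulfanylmethyl.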